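The source may report more compounds than this note shows. Statements on the series, on what has been measured and on what is new or still open speak of the compounds shown alone.

Measured so far in a functional assay on the whole organism with Mus musculus as the target, in the writhing test; on this read-out lower numbers stand for an effect already at smaller amounts and higher numbers for an effect only at larger amounts of compound:
- compound 1 `FC(F)(F)CCCSc1nsnc1C1CN2CCCC1C2` gives 0.1 mg/kg
- compound 2 `FC(F)(F)CCCSc1nsnc1[C@H]1CN2CCC[C@@H]1C2` gives 1.8 mg/kg
- compound 3 `CCCCSc1nsnc1[C@@H]1CN2CCC[C@@H]1C2` gives 0.19 mg/kg

Among the compounds with values here, the number for compound 3 lies within the scatter of that for compound 1 and well under the one for compound 2 .

Compound 4 `FC(F)(F)CCCSc1nsnc1[C@@H]1CN2CCC[C@@H]1C2` differs from compound 3 by trifluoromethyl in place of methyl on a saturated chain carbon, three bonds along the chain from a sulfur, which turns butyl into 4,4,4-trifluorobutyl. Within the data shown here, the only measured step, an 18-fold higher number from compound 1 to compound 2 (1.26 log units; beyond the scatter), is large and goes with the fact that one of compounds 1 and 2 is drawn with a defined configuration and the other without, at the place where they differ. The chain is the same on both sides of that step, so it does not test this change. Among the measured compounds shown here, no measured step does. The nearest guide is compound 1 at 0.1 mg/kg, which carries the 4,4,4-trifluorobutyl chain and sits within the scatter of compound 3 . No step beyond the scatter is therefore expected in this assay, with a slight lean towards a lower number. The expected change is a 1.6-fold lower number from compound 3 to compound 4 (0.20 log units; within the scatter). The estimated value for compound 4 is 0.12 mg/kg, with an expected range of 0.04 mg/kg to 0.4 mg/kg.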

Compound 4, dose for half-maximal effect: 0.35 mg/kg
Beside the measured number, compound 4's estimate is 2.9-fold (0.46 log units) below it; low and high end bracket the measured number.
By their numbers in this assay, from the lowest: compounds 1, 3 and 4 (each within the scatter of the next, the first and the last beyond it); then compound 2.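

In this assay, trifluoromethyl in place of methyl gives a 1.8-fold higher number from compound 3 to compound 4 (0.27 log units; within the scatter), so with the configuration held, butyl and 4,4,4-trifluorobutyl are not separated at this position. With the 4,4,4-trifluorobutyl chain held, a 5.1-fold lower number from compound 2 to compound 4 (0.71 log units; beyond the scatter) is a step beyond the scatter that goes with a single stereocentre: the fact that one of compounds 2 and 4 is drawn with a defined configuration and the other without, at the place where they differ. Likewise, a 3.5-fold higher number from compound 1 to compound 4 (0.54 log units; beyond the scatter) lies beyond the scatter, so among the compounds with this chain the number shifts with the stereo drawing alone, while the chain change itself stays within the scatter: the fact that one of compounds 1 and 4 is drawn with a defined configuration and the other without, at the place where they differ.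

Still open, as far as these compounds go, is whether the change from butyl to 4,4,4-trifluorobutyl reads the same in the configuration of compound 2, and which configuration accounts for the low number of compound 1. Also open, from the compounds shown here alone, is how a longer chain, or an amine or a carboxylic acid in place of trifluoromethyl, would read in this assay's terms, this assay.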